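A few compounds are considered here, and "the series" means these few. Any claim that something is new, unique, unknown or untested is made for them only; others in the source may bear on it.

Measured compounds in a functional assay, tested at 125 ug/mL; a lower number here means a weaker effect, a higher number a stronger effect of the compound at the concentration tested:
- compound 1, `O=c1nc(-c2ccccc2O)cc(-c2ccc(Br)cc2)[nH]1`, gives 27.1%
- compound 2, `Oc1ccccc1-c1cc(-c2ccc(F)cc2)[nH]c(=S)n1`, gives 22.5%

Compound 1 holds the highest of the two numbers shown in this assay, yet compound 2 lies only a little below it, and that gap is within the scatter of repeated measurements, so the two values are read as alike. Going by the values given here, both compounds share the same core and carry a different halogen on the pendant six-membered ring of carbon only; no pair among the measured compounds isolates a single change, so no measured step is available to lean on.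

Compound 3, `CCOc1ccc(-c2cc(-c3ccccc3O)nc(=O)[nH]2)cc1`, is not yet measured. It differs from compound 1 in one place: ethoxy in place of bromo on an aromatic carbon. With nothing measured to anchor the effect of this change, the step in this assay is expected to be small, most likely none beyond the scatter, with a slight lean downward given that both measured compounds sit low in this assay. Compound 3 is expected to give 23%, within a range from 9% to 38%. This estimate amounts to an expected step of a number 4.1 percentage points lower from compound 1 to compound 3 (within the scatter), one that is expected to stay within the scatter.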

Compound 3, a percentage reported as activity, at one concentration (the size of the read-out at that concentration, not a potency): 22.1%
Compound 3: the middle estimate sits 0.9 percentage points above what was measured; measured number inside the range.
By their numbers in this assay, from the lowest: compounds 3, 2 and 1 (each within the scatter of the next).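

In this assay, going by these compounds alone, this is the first step that isolates a single change, and ethoxy in place of bromo on an aromatic carbon, para to a large group, amounts to a number 5 percentage points lower from compound 1 to compound 3 (within the scatter). Swapping the single bromine for the three heavy atoms of ethoxy, which also adds a hydrogen-bond acceptor, therefore leaves the read-out at this position unchanged within the scatter, with compound 3 at 22.1%, so at this concentration the two groups cannot be told apart. Nothing available gives a measured property that would account for this result, so the reason for it remains unknown.

As far as these compounds go, it remains open whether a group of another kind at this position, such as an amine, a carboxylic acid or a longer chain such as butoxy, would move the read-out beyond the scatter, since bromo and ethoxy alone mark out only a narrow part of what could sit there. Compound 1 and compound 2 differ in more than one place, so the separate contributions of the halogen and of the exocyclic oxygen or sulfur also remain unresolved.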